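Replacing an Aminopropenyl Chain With an Oxetane-Bearing Group

The source may report more compounds than this note shows. Statements on the series, on what has been measured and on what is new or still open speak of the compounds shown alone.

Measured compounds:
compound 1 `CN(C[C@H]1Cc2ncccc2CN1)[C@H]1CCCc2cccnc21` gives 95% in an ADME assay on microsomes from liver (Homo sapiens) for metabolic stability, using NADPH, with a stated time of 10 min; on this read-out higher numbers stand for a more stable compound and lower numbers for a less stable compound;
compound 2 `NC/C=C\CN(C[C@H]1Cc2ncccc2CN1)[C@H]1CCCc2cccnc21` gives 85% in this assay.

Compound 2 holds the lower of the two numbers, and its nearest neighbour is compound 1, the step being a number 10 percentage points lower from compound 1 to compound 2 (within the scatter). Compound 3 `c1cnc2c(c1)CN[C@@H](CN(CCCCNC1COC1)[C@H]1CCCc3cccnc31)C2` differs from compound 2 by a group of 8 heavy atoms (6 carbon, 1 nitrogen, 1 oxygen; one four-membered non-aromatic ring with 1 hetero atom) in place of a group of 4 heavy atoms (3 carbon, 1 nitrogen; no ring), on a saturated chain carbon bound to an amine nitrogen. Among the compounds with values here, the only measured step, a number 10 percentage points lower from compound 1 to compound 2 (within the scatter), concerns a different group at the same place and stayed within the scatter, so no step speaks directly to the new group. Compound 3 is therefore expected to give about 75%, ranging from 50% to 95%. This estimate means an expected step of a number 10 percentage points lower from compound 2 to compound 3 (within the scatter), a small downward shift that may not exceed the scatter.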

Compound 3, percent of the compound remaining: 97%
Estimate against measurement, compound 3: 22 percentage points below; measured number outside the range, above it.
By their numbers in this assay, from the lowest: compounds 2, 1 and 3 (each within the scatter of the next, the first and the last beyond it).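

In this assay, within the data shown here, the reading shows a number 12 percentage points higher from compound 2 to compound 3 (beyond the scatter) and so gives the first step at this place, on a saturated chain carbon bound to an amine nitrogen, that lies beyond the scatter. Against the hydrogen atom, the same group of 8 heavy atoms with its four-membered ring shows a number 2 percentage points higher from compound 1 to compound 3 (within the scatter) and so brings no readable change. No supporting evidence is available to explain these numbers.

As far as these compounds go, what remains open is whether the four-membered ring itself matters, or whether a plain butylamine chain would read the same. A carboxylic acid at this place also remains untested by the compounds shown here.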